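Aryl swap on the saturated ring carbon: compound 4

The compounds below may be only part of what the source reports. "The series", "measured", "known", "first", "only" and "open" are said of these compounds alone.

Compound 1 `CC1=C(C(=O)Nc2ccc(Br)cc2)C(c2ccc(Cl)cc2Cl)N=C(SCc2ccccc2Cl)N1` in a functional assay on the whole organism (artery, strain albino) with Rattus norvegicus as the target, with a stated time of 15 min, at a dose of 10 mg/kg by the oral route (a lower number here means less inhibition, a higher number more inhibition at the dose given (going by the name of the read-out)), gives 3.1%. Compound 2 `CC1=C(C(=O)Nc2ccc(Br)cc2)C(c2ccc(Cl)cc2Cl)N=C(SCc2cccc(Cl)c2)N1` gives 1.5%, and compound 3 `CC1=C(C(=O)Nc2ccc(Br)cc2)C(c2ccc(Cl)cc2Cl)N=C(SCc2ccc(F)cc2)N1` gives 3.6%. Compound 1 sits within the scatter of both neighbours: a number 1.6 percentage points lower from compound 1 to compound 2 (within the scatter) and a number 0.5 percentage points higher from compound 1 to compound 3 (within the scatter), and likewise a number 2.1 percentage points higher from compound 2 to compound 3 (within the scatter). Compound 4 `COc1ccc(C2N=C(SCc3ccccc3Cl)NC(C)=C2C(=O)Nc2ccc(Br)cc2)cc1` differs from compound 1 in one place: 4-methoxyphenyl in place of 2,4-dichlorophenyl on a saturated ring carbon. For the measured compounds named here, no measured step touches this ring position; the three measured steps all vary the aryl on the saturated chain carbon bound to a sulfur, and none moves beyond the scatter. Nothing in the series supports a step beyond the scatter in this assay. The expected step from compound 1 to compound 4 is a number 0.1 percentage points lower from compound 1 to compound 4 (within the scatter). Compound 4 is estimated at 3%, within -5% to 12%.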

Compound 4, a percentage reported as inhibition, in the whole organism at one dose (the size of the read-out at that dose, not a potency): 3.1%
For compound 4 the middle estimate is 0.1 percentage points below the measured one; measured number inside the range.
By their numbers in this assay, from the lowest: compounds 2, 1, 4 and 3 (each within the scatter of the next).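

In this assay, the saturated ring carbon now has a measured step of its own: 4-methoxyphenyl in place of 2,4-dichlorophenyl gives no change at the digits printed from compound 1 to compound 4 (within the scatter). This swap removes both chlorine atoms and brings in a methoxy oxygen, yet the number does not leave the scatter, so the aryl at this carbon can change in this way without a readable step. Nothing measured here bears on the reason for this result.

Still open, from the compounds shown here alone, is whether a cyclohexyl group or a longer alkyl chain on this ring carbon would give a step beyond the scatter. Going by these compounds, an amine or carboxylic acid on this aryl ring is equally open.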